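Putting an Aryl Group Back onto Compound 2

The source may report more compounds than this note shows. Statements on the series, on what has been measured and on what is new or still open speak of the compounds shown alone.

Measured so far in an assay for inhibition of MAP kinase-interacting serine/threonine-protein kinase 1 (Homo sapiens), read by luminescence and ADP-Glo, with a stated time of 2 h; on this read-out lower numbers stand for stronger inhibition and higher numbers for weaker inhibition:
compound 1 `O=c1ccc(-c2ccc3cn[nH]c3c2)cn1Cc1cccc(F)c1` gives 74 nM
compound 2 `Cn1cc(-c2ccc3cn[nH]c3c2)ccc1=O` gives > 2000 nM

The value of compound 2 is a limit of the assay rather than a number (the limit of > 2000 nM in this assay, at which 1 of the 2 values shown sits), and on the numbers shown compound 2 therefore stands at the weak end. Compound 3 `O=c1ccc(-c2ccc3cn[nH]c3c2)cn1Cc1ccc(Cl)c(Cl)c1` differs from compound 2 by 3,4-dichlorophenyl in place of hydrogen on a saturated chain carbon bound to an aromatic nitrogen. Among the compounds with values here, only one measured step bears on this change, and it runs the opposite way: an at least 27-fold higher number from compound 1 to compound 2 (1.43 log units; beyond the scatter), where taking 3-fluorophenyl off that same carbon pushed the value out to the limit. Given an at least 27-fold higher number from compound 1 to compound 2 (1.43 log units; beyond the scatter), a large fall in this assay, toward stronger inhibition, is expected when 3,4-dichlorophenyl is placed on that carbon in compound 3. Compound 3 is accordingly estimated at 60 nM, with a plausible range from 15 nM to 250 nM. That estimate for compound 3 means an expected step of an at least 33-fold lower number from compound 2 to compound 3 (1.52 log units; beyond the scatter).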

Compound 3, half-maximal inhibitory concentration: 62 nM
Estimate against measurement, compound 3: 1.0-fold (0.01 log units) below; the range from low to high includes it.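

Within the data shown here, compound 1's 3-fluorophenyl is not the only aryl group that works here: in this assay, placing 3,4-dichlorophenyl on the saturated chain carbon bound to the aromatic nitrogen gives an at least 32-fold lower number from compound 2 to compound 3 (1.50 log units; beyond the scatter). The true size of that step stays unknown, because compound 2 sits at a limit of the assay rather than at a number: the limit of > 2000 nM in this assay, at which 1 of the 3 values shown sits.

Exchanging one aryl group for the other gives a 1.2-fold lower number from compound 1 to compound 3 (0.08 log units; within the scatter), so a single fluorine and two chlorines on the ring read alike at this position.

Still open, on these data alone, is whether an unsubstituted phenyl, a pyridine ring or a longer chain carrying the phenyl would perform as well. The compounds shown also do not separate what the ring itself contributes from what its halogen atoms contribute.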